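This account rests on a few compounds, and the source may have more. Where it says the series, first, only, none or still open, it means among the compounds named here.

Measured so far:
compound 1 `NC(=O)c1c(NC(=O)c2ccccc2Cl)sc2c1CCN(Cc1ccccc1)C2` — 12000 nM
compound 2 `NC(=O)c1c(NC(=O)c2cccc([N+](=O)[O-])c2)sc2c1CCN(Cc1c(Cl)cccc1Cl)C2` — 18400 nM

Both values come from a functional assay on HL-60 cells (Homo sapiens) for antiproliferative activity, with a stated time of 24 h; a higher number here means a weaker inhibitor, a lower number a stronger inhibitor. Compound 1 and compound 2 lie within the scatter of each other, so neither can be called the stronger; both sit in the same weak range. Compound 3 `NC(=O)c1c(NC(=O)c2ccccc2Cl)sc2c1CCN(C(=S)Nc1ccccc1F)C2` is not yet measured. It differs from compound 1 by a group of 10 heavy atoms (7 carbon, 1 nitrogen, 1 fluorine, 1 sulfur; one six-membered aromatic ring of carbon only) in place of a group of 7 heavy atoms (7 carbon; one six-membered aromatic ring of carbon only), on an amine nitrogen in a ring. Among the measured compounds shown here, no step between measured compounds covers this change, so its effect is unknown; a step of modest size in either direction, or none beyond the scatter, is expected. Compound 3 is estimated at 10000 nM, between 3000 nM and 35000 nM, which means an expected step of a 1.2-fold lower number from compound 1 to compound 3 (0.08 log units; within the scatter).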

Compound 3, half-maximal inhibitory concentration: 4970 nM
Beside the measured number, compound 3's estimate is 2.0-fold (0.30 log units) above it, and the stated range covers the measured number.
By their numbers in this assay, from the lowest: compound 3; then compounds 1 and 2 (each within the scatter of the next).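

In this assay, the amine nitrogen in a ring proves open to change: the benzyl group can give way to the larger, sulfur- and fluorine-bearing group of compound 3 with a 2.4-fold lower number from compound 1 to compound 3 (0.38 log units; beyond the scatter) as the result. Among the compounds shown here, this is the first step beyond the scatter, and it is modest. No measurement bears on what lies behind it.

Which part of the new group carries the step stays open. A urea with oxygen in place of sulfur, or an unsubstituted phenyl ring in place of the fluorinated one, would separate these parts.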